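Swapping one aromatic group on a clearance series

The source may hold more compounds than are shown below. What is called first, only, known or untested is meant among the compounds shown, and "the series" means these compounds.

Measured in an ADME assay (liver) for metabolic stability, with Liver microsome (Rattus norvegicus) as the target, using microsomes and NADPH, with a stated time of 30 min, tested at 1 uM; a higher number here means faster removal of the compound, a lower number slower removal:
- compound 1 `CC(C)(C)n1cc(-c2cc(C(O)(C(F)(F)F)C(F)(F)F)cnc2N2CCN(S(=O)(=O)c3ccc(N)nc3)CC2)cn1`: 459 mL.min-1.g-1
- compound 2 `NC(=O)c1cccc(-c2cc(C(O)(C(F)(F)F)C(F)(F)F)cnc2N2CCN(S(=O)(=O)c3ccc(N)nc3)CC2)c1`: 63 mL.min-1.g-1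
- compound 3 `Cc1ccc(-c2cc(C(O)(C(F)(F)F)C(F)(F)F)cnc2N2CCN(S(=O)(=O)c3ccc(N)nc3)CC2)cn1`: 182 mL.min-1.g-1

Compound 3 holds the middle place of these three numbers, with a 2.5-fold lower number from compound 1 to compound 3 (0.40 log units; beyond the scatter) and a 2.9-fold higher number from compound 2 to compound 3 (0.46 log units; beyond the scatter). Compound 4 `Nc1ccc(S(=O)(=O)N2CCN(c3ncc(C(O)(C(F)(F)F)C(F)(F)F)cc3-c3ccc4ocnc4c3)CC2)cn1` keeps the shared core and differs from compound 3 in one group: 1,3-benzoxazol-5-yl in place of 6-methylpyridin-3-yl on an aromatic carbon. The group that changes sits on an aromatic carbon, and all three measured steps are swaps of the group at this same place. The largest is a 7.3-fold lower number from compound 1 to compound 2 (0.86 log units; beyond the scatter), and the smallest is a 2.5-fold lower number from compound 1 to compound 3 (0.40 log units; beyond the scatter). Such swaps can clearly move the number, yet no measured compound carries 1,3-benzoxazol-5-yl, so the data give no direction for this change. The best guess therefore stays close to compound 3, with a wide margin on both sides. In this assay, the expected change is no more than scatter, and the estimate is a 1.0-fold higher number from compound 3 to compound 4 (0.02 log units; within the scatter). For compound 4 the estimated value is 190 mL.min-1.g-1, with an expected range from 80 mL.min-1.g-1 to 430 mL.min-1.g-1.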

Compound 4, intrinsic clearance in microsomes: 120 mL.min-1.g-1
The estimate for compound 4 lay 1.6-fold (0.20 log units) above the measured number; measured number inside the range.
By their numbers in this assay, from the lowest: compounds 2, 4 and 3 (each within the scatter of the next, the first and the last beyond it); then compound 1.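

In this assay, replacing 6-methylpyridin-3-yl with 1,3-benzoxazol-5-yl on this aromatic carbon gives a 1.5-fold lower number from compound 3 to compound 4 (0.18 log units; within the scatter) and replacing 3-carbamoylphenyl with it gives a 1.9-fold higher number from compound 2 to compound 4 (0.28 log units; within the scatter) so neither change separates compound 4 from the compound it is set against. A group with two fused aromatic rings, a kind not seen at this position before, can therefore sit here with a number that cannot be told apart from those of the two six-membered-ring groups. Only the replacement of 1-(tert-butyl)-1H-pyrazol-4-yl gives a step beyond the scatter, with a 3.8-fold lower number from compound 1 to compound 4 (0.58 log units; beyond the scatter) as its size.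

From the compounds shown here alone, it remains open where a simple amine or a carboxylic acid on the same aromatic carbon would fall in this order. Nothing else measured on these compounds offers a reason for the numbers.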